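The compounds below may be only part of what the source reports. "The series", "measured", "known", "first", "only" and "open" are said of these compounds alone.

In a functional assay on HCT-116 cells (Homo sapiens) for antiproliferative activity, read by MTT assay, with a stated time of 72 h (a lower number here means a stronger inhibitor, a higher number a weaker inhibitor), the measured compounds are:

Compound 1 `NC1=NC2(CCSCC2)N(OCCCOc2ccc(Cl)c(Cl)c2)C(N)=N1`: 1 nM
Compound 2 `NC1=NC2(CCSCC2)N(OCCCOc2cccc(Cl)c2)C(N)=N1`: 1 nM
Compound 3 `NC1=NC2(CCSCC2)N(OCCCOc2cc(Cl)c(Cl)cc2Cl)C(N)=N1`: 1 nM

Compound 3 stands level with compounds 1 and 2. Compound 4 `NC1=NC2(CCSCC2)N(OCCCOc2ccccc2Br)C(N)=N1` carries 2-bromophenyl in place of 2,4,5-trichlorophenyl on an oxygen on a saturated carbon. The three measured steps all alter the chloro substitution on the aromatic ring, and none moves the value: no change at the digits printed from compound 1 to compound 2 (within the scatter), no change at the digits printed from compound 1 to compound 3 (within the scatter) and no change at the digits printed from compound 2 to compound 3 (within the scatter). For the measured compounds named here, no measured compound carries bromo, so this evidence is indirect. The expected change is no change at the digits printed from compound 3 to compound 4 (within the scatter), and no step beyond the scatter is expected in this assay. The estimate for compound 4 is 1 nM, with an expected range of 0.5 nM to 4 nM.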

Compound 4, half-maximal inhibitory concentration: 1 nM
Estimate against measurement, compound 4: no gap at the digits printed, and the stated range covers the measured number.
By their numbers in this assay, from the lowest: compounds 1, 2, 3 and 4 (each within the scatter of the next).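

In this assay, 2-bromophenyl on an oxygen on a saturated carbon gives no change at the digits printed from compound 3 to compound 4 (within the scatter) and no change at the digits printed from compound 2 to compound 4 (within the scatter) and no change at the digits printed from compound 1 to compound 4 (within the scatter) in the same read-out. Compound 4 is the first shown with bromine on this ring, and it carries one halogen where compound 3 carries three, so the position accepts this exchange of halogen and the smaller group without a step beyond the scatter. No measurement here explains this tolerance. The compounds shown leave open whether an amine or a carboxylic acid on this ring would hold the value. They also leave open whether a longer chain to the ring would do so.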